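One added fluoro on a compound at the limit

A few compounds are considered here, and "the series" means these few. Any claim that something is new, unique, unknown or untested is made for them only; others in the source may bear on it.

Compound 1 `Fc1ccc(Nc2cc3[nH]c(-c4cccc(C(F)(F)F)c4)nc3cn2)nc1` is the starting point. In a physicochemical assay for solubility, using the shake flask method, in simulated intestinal fluid, measured as kinetic solubility, with a stated time of 20 h, at pH 6.5 (a higher number here means a more soluble compound, a lower number a less soluble compound), compound 1 gives >= 50000 nM, which is a limit of the assay and not a number. Its close relative, compound 2 `N#Cc1ccc(Nc2cc3[nH]c(-c4cccc(C(F)(F)F)c4)nc3cn2)nc1`, gives >= 50000 nM in this assay, and this too is a limit. Both measured compounds therefore stand at the same mark: the limit of >= 50000 nM in this assay, at which 2 of the 2 values shown sit. Among the compounds with values here, the only measured step, a step that the two limits leave unreadable from compound 1 to compound 2, puts cyano in place of fluoro on an aromatic carbon, so it offers no size to carry forward.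

Compound 3 `Fc1ccc(Nc2cc3[nH]c(-c4ccc(F)c(C(F)(F)F)c4)nc3cn2)nc1` changes a different place: fluoro in place of hydrogen on an aromatic carbon. Here fluoro replaces hydrogen on an aromatic carbon, ortho to a trifluoromethyl group and para to a large group. Within the data shown here, no measured step covers this change. The expectation thus rests on compound 1 alone, whose >= 50000 nM is a limit. The expected change in this assay is an at least 1.1-fold lower number from compound 1 to compound 3 (0.04 log units; that floor lies within the scatter), with no step beyond the scatter and no direction foreseen. For compound 3 the estimate is 45000 nM, with an expected range from 18000 nM to 60000 nM.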

Compound 3, solubility: >= 50000 nM
Compound 3: a limit, no number (the forecaster's own chance of this, stated with the estimate: 70%); middle value at least 1.1-fold (0.04 log units) away from the limit.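

In this assay compound 3 gives >= 50000 nM, which is a limit of the assay and not a number. The step from compound 1 to compound 3 therefore cannot be read. The compounds shown leave open how far past this mark each one lies, and whether either change moves the read-out at all: the limit of >= 50000 nM in this assay, at which 3 of the 3 values shown sit.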